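Bromo to Methoxy on Compound 3's Aromatic Ring

The source may hold more compounds than are shown below. What is called first, only, known or untested is meant among the compounds shown, and "the series" means these compounds.

In a functional assay on NCI-H460 cells (Homo sapiens) for cytotoxicity, read by MTT assay, with a stated time of 72 h (a higher number here means a weaker inhibitor, a lower number a stronger inhibitor), compound 3 `CN(C)CCn1cnnc1-c1cc(Oc2ccc(NC(=O)N/N=C/c3ccc(O)c(Br)c3)cc2F)ccn1` gives 430 nM, the lowest of the three numbers measured. Compound 2 `CN(C)CCn1cnnc1-c1cc(Oc2ccc(NC(=O)N/N=C/c3ccc(F)cc3Cl)cc2F)ccn1` gives 720 nM, which sits within the scatter of compound 3, while compound 1 `COc1ccc(OC)c(/C=N/NC(=O)Nc2ccc(Oc3ccnc(-c4nncn4CCN(C)C)c3)c(F)c2)c1` gives 2930 nM and is clearly weaker, because a 6.8-fold lower number from compound 1 to compound 3 (0.83 log units; beyond the scatter) and a 4.1-fold lower number from compound 1 to compound 2 (0.61 log units; beyond the scatter). Compound 4 `COc1cc(/C=N/NC(=O)Nc2ccc(Oc3ccnc(-c4nncn4CCN(C)C)c3)c(F)c2)ccc1O` differs from compound 3 by methoxy in place of bromo on an aromatic carbon. Among the measured compounds shown here, no measured step isolates this exchange; each measured step replaces the whole aromatic group. The closest guide is a 1.7-fold lower number from compound 2 to compound 3 (0.22 log units; within the scatter), a small change from one substituted ring to another. The estimated step is therefore modest, a 1.5-fold higher number from compound 3 to compound 4 (0.18 log units; within the scatter), with no change beyond the scatter expected. Compound 4 is expected to give 650 nM, in a range from 250 nM to 1700 nM.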

Compound 4, half-maximal inhibitory concentration: 57 nM
Compound 4: middle estimate off by 11-fold (1.06 log units), on the high side, outside the stated range (below it).
By their numbers in this assay, from the lowest: compound 4; then compounds 3 and 2 (each within the scatter of the next); then compound 1.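

In this assay, the group on this aromatic carbon carries far more weight than the earlier exchanges of whole rings suggested: with the hydroxy group kept, methoxy in place of bromo gives a 7.5-fold lower number from compound 3 to compound 4 (0.88 log units; beyond the scatter). The 4-hydroxy-3-methoxyphenyl group also stands clear of the other two rings, with a 13-fold lower number from compound 2 to compound 4 (1.10 log units; beyond the scatter) and a 51-fold lower number from compound 1 to compound 4 (1.71 log units; beyond the scatter). No measurement at hand explains this gain. Still open, going by these compounds, is whether an ethoxy group or an amine on this carbon would keep the number as low. Whether the methoxy group needs the hydroxy group to do so is also unknown.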